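A few compounds are considered here, and "the series" means these few. Any claim that something is new, unique, unknown or untested is made for them only; others in the source may bear on it.

In an ADME assay (Fibroblast) for cytotoxicity, with Homo sapiens as the target (on this read-out higher numbers stand for weaker inhibition and lower numbers for stronger inhibition), three compounds have been examined so far, and none of them yields a number. Compound 1 `CC(=O)OCCOCn1cc(C#N)c2c(N)ncnc21` gives only a limit of the assay, > 100000 nM. Compound 2 `N#Cc1cnc2n(COCCO)cnc(N)c1-2` likewise returns a limit, > 320000 nM. Compound 3 `NC(=NO)c1cn(COCCO)c2ncnc(N)c12` also ends at a limit, > 100000 nM. Where compound 3 stands among the three is therefore not a value but a bound, the same one at which compound 1 sits (the limit of > 100000 nM in this assay, at which 2 of the 3 values shown sit); compound 2 sits at a different bound (the limit of > 320000 nM in this assay, at which 1 of the 3 values shown sits). For the measured compounds named here, no measured pair differs in just one place, so no step in this assay has yet been sized.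

Compound 4 `NNC(=O)c1cn(COCCO)c2ncnc(N)c12` remains to be measured. It differs from compound 3 by a group of 4 heavy atoms (1 carbon, 2 nitrogen, 1 oxygen; no ring) in place of a group of 4 heavy atoms (1 carbon, 2 nitrogen, 1 oxygen; no ring), on an aromatic carbon: the two have the same atoms, joined differently, a group of 4 heavy atoms (1 carbon, 2 nitrogen, 1 oxygen; no ring) in place of a group of 4 heavy atoms (1 carbon, 2 nitrogen, 1 oxygen; no ring), on an aromatic carbon. With every value shown being a limit, the step expected from compound 3 to compound 4 is a step that the limit leaves unreadable from compound 3 to compound 4, that is, none beyond the scatter. For compound 4 the estimate in this assay is 150000 nM, ranging from 50000 nM to 500000 nM, and most likely again only a limit.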

Compound 4, half-maximal inhibitory concentration: > 100000 nM
Compound 4: no number, only a limit; the forecaster's own chance of this, stated with the estimate: 85%; the middle value does not contradict the limit.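

For the compounds shown here, compound 3 and compound 4 both end at a limit in this assay, and no step between them can be read. The compounds shown leave open where any of the four would reach a true half-maximal value in this assay, and whether exchanging these groups changes anything there.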